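Adding a third methoxy group to the carbonyl-side ring

This account rests on a few compounds, and the source may have more. Where it says the series, first, only, none or still open, it means among the compounds named here.

Measured compounds:
Compound 1 `COc1cc(-c2cc(/C=C/C(=O)c3ccc(Cl)c(Cl)c3)[nH]n2)cc(OC)c1OC`: 8%
Compound 2 `COc1ccc(-c2cc(/C=C/C(=O)c3cc(OC)c(OC)c(OC)c3)[nH]n2)cc1OC`: -10%
Compound 3 `COc1ccc(C(=O)/C=C/c2cc(-c3cc(OC)c(OC)c(OC)c3)n[nH]2)cc1OC`: 2%

In a functional assay on SR cells (Homo sapiens) for cytotoxicity, read by sulforhodamine B assay, with a stated time of 48 h, tested at 10 uM (a higher number here means a weaker effect of the compound at the concentration tested, a lower number a stronger effect), compound 3 stands second highest of the three numbers. Its nearest neighbour is compound 1, which gives 8%; the step of a number 6 percentage points lower from compound 1 to compound 3 (within the scatter) lies within the scatter, so the two cannot be told apart. Compound 2 lies furthest away and gives -10%, a number beyond the scatter below compound 3.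

The next compound, compound 4 `COc1cc(C(=O)/C=C/c2cc(-c3cc(OC)c(OC)c(OC)c3)n[nH]2)cc(OC)c1OC`, is not yet measured. It differs from compound 3 by methoxy in place of hydrogen on an aromatic carbon.

Going by the values given here, no measured step covers this exchange of a hydrogen for a methoxy group: the only measured step, from compound 1 to compound 3, swaps a whole substituted phenyl ring on the carbonyl carbon, and it stayed within the scatter. All three measured numbers are low, and compound 2, which also carries a trimethoxyphenyl on its carbonyl carbon, gives a number in the same low region. The expectation for this assay is therefore no step beyond the scatter, in either direction.

Compound 4 is thus expected to give about 0%, within a range of -15% to 15%, which is an estimated step of a number 2 percentage points lower from compound 3 to compound 4 (within the scatter).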

Compound 4, a percentage reported as activity, at one concentration (the size of the read-out at that concentration, not a potency): 12%
The estimate for compound 4 lay 12 percentage points below the measured number, within the range that was stated.
By their numbers in this assay, from the lowest: compound 2; then compounds 3, 1 and 4 (each within the scatter of the next).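

In this assay, a methoxy group in place of hydrogen on the ring attached to the carbonyl carbon gives a number 10 percentage points higher from compound 3 to compound 4 (within the scatter) and so does not separate the two compounds. Going by these compounds alone, the same exchange on the other substituted phenyl ring gives a number 22 percentage points higher from compound 2 to compound 4 (beyond the scatter) and is the first sign that adding a methoxy group can shift the number, here towards a weaker effect at the concentration tested. Nothing available here explains why one exchange stays within the scatter and the other does not.

These compounds leave open whether the shift belongs to methoxy itself or would also appear with another group at that position, such as a hydroxyl group, an amine or a longer ethoxy chain. Within the data shown here, each compound is also described by a single reading at one concentration, so how their potencies compare remains unknown, and compound 4 with its two trimethoxyphenyl rings is the only compound that shows both exchanges.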